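A few compounds are considered here, and "the series" means these few. Any claim that something is new, unique, unknown or untested is made for them only; others in the source may bear on it.

Series with a shared core, measured so far:
- compound 1 `O=C(CCCCC(S)CCS)NO`: 9.12%
- compound 2 `O=C(CCCCC(S)CCS)Nc1ccccc1`: 1.32%
- compound 3 `O=C(CCCCC(S)CCS)Nc1ccccc1Cl`: 3.08%

These values come from a functional assay on Bel-7402 cells (Homo sapiens) for inhibition, read by MTT assay, with a stated time of 24 h, tested at 1 ug/mL; a lower number here means less inhibition of growth, a higher number more inhibition of growth at the concentration tested. Compound 2, at 1.32%, lies within the scatter of both other compounds, so the three numbers cannot be ranked.

The next compound is compound 4 `O=C(CCCCC(S)CCS)Nc1ccc(Cl)cc1`, which differs from compound 2 as follows: chloro in place of hydrogen on an aromatic carbon. In words, this is chloro in place of hydrogen on an aromatic carbon, para to a large group.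

Within the data shown here, the closest precedent is a number 1.8 percentage points higher from compound 2 to compound 3 (within the scatter), the same replacement at another place on the ring. The other measured step, a number 7.8 percentage points lower from compound 1 to compound 2 (within the scatter), changes a different part of the molecule and bears on this question only by showing how little the numbers have moved so far.

With that precedent from compound 3 at 3.08%, no step beyond the scatter is expected, and no direction can be claimed. The expected step is a number 1.7 percentage points higher from compound 2 to compound 4 (within the scatter).

For compound 4 the estimated value is 3%, with an expected range from 0% to 9%.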

Compound 4, percent growth inhibition at one concentration: 0.27%
Estimate against measurement, compound 4: 2.7 percentage points above; measured number inside the range.
By their numbers in this assay, from the lowest: compounds 4, 2, 3 and 1 (each within the scatter of the next).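

In this assay, chloro in place of hydrogen on an aromatic carbon, para to a large group, gives a number 1.1 percentage points lower from compound 2 to compound 4 (within the scatter). The same replacement elsewhere on the ring gives a number 1.8 percentage points higher from compound 2 to compound 3 (within the scatter), so chloro has now been tried at two ring places without a step beyond the scatter, and the opposite signs of the two steps carry no meaning. No measurement on hand bears on the reason for this result.

Among these compounds, whether any change to this series can give a step beyond the scatter remains open, since all the steps so far lie within it. An amine or a carboxylic acid on the aromatic ring in place of chloro, or a longer chain in the shared core, would test this.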